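The compounds below may be only part of what the source reports. "The series", "measured", "known", "first", "only" and "open" are said of these compounds alone.

Of the compounds shown here, three have so far been measured in a physicochemical assay for acid dissociation, read by capillary electrophoresis, tested at 100 uM. Compound 1 `Oc1ccccc1SCc1ccccc1` gives 9.06. Compound 3 `O=C1NC(=O)C(Cc2ccccc2)O1` gives 5.86. Compound 2 `O=C1C=C(O)CC1Cc1ccccc1` gives 4.01, the lowest of the three numbers; its nearest neighbour is compound 3, whose value stands higher by a margin beyond the scatter, and the furthest is compound 1, higher again by a margin well beyond the scatter. No two of these compounds differ in a single place, so no measured step stands behind the change now considered.

Compound 4 `CC1=C(O)CC(Cc2ccccc2)C1=O` is the next compound, not yet measured in this assay. It differs from compound 2 as follows: methyl in place of hydrogen on a double-bonded ring carbon. The hydroxy group of the shared core remains in place; only the methyl is added, on a double-bonded ring carbon of the five-membered non-aromatic ring.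

Nothing measured here shows what such a change does to the acid dissociation constant. The account therefore expects only a small step in this assay, probably upward, and possibly no larger than the scatter. Compound 4 is expected to give 4.5, within a range from 3.9 to 5.2. That estimate corresponds to an expected step of a number 0.49 log units higher from compound 2 to compound 4 (beyond the scatter).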

Compound 4, acid dissociation constant: 4.47
For compound 4 the middle estimate is 0.03 log units above the measured one, and the stated range covers the measured number.
By their numbers in this assay, from the lowest: compound 2; then compound 4; then compound 3; then compound 1.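

In this assay, for the compounds shown here, methyl in place of hydrogen on a double-bonded ring carbon gives the first step that can be read, a number 0.46 log units higher from compound 2 to compound 4 (beyond the scatter), so this place, next to the ring atom that bears a hydroxy group, is one where a single added carbon moves the read-out, though only modestly. The methyl brings no hydrogen-bond donor, no hydrogen-bond acceptor and no net charge, and the hydroxy group of the shared core remains in place, yet the step still lies beyond the scatter. Nothing measured here says what lies behind this step, which stands as an observation from one pair of compounds.

Whether an ethyl group, a longer chain, a chlorine atom or a methoxy group at this same place would move the number further, or the other way, remains open, as the compounds shown carry only the methyl here. Also open, from the compounds shown here alone, is whether the methyl would give a step of similar size if an amine or a carboxylic acid stood in place of the group of 7 heavy atoms, two ring bonds away.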